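Side-chain variation at the benzylic position of the thiazolyl amide

The source may report more compounds than this note shows. Statements on the series, on what has been measured and on what is new or still open speak of the compounds shown alone.

Compound 3 `COCC[C@H](C(=O)Nc1nccs1)c1ccc(Cl)cc1` gives 170000 nM in a functional assay on CHO cells for agonist activity at Free fatty acid receptor 2 (Homo sapiens), read by cAMP accumulation (on this read-out lower numbers stand for stronger inhibition and higher numbers for weaker inhibition), the highest number among the three measured. Compound 1 `C[C@H](C(=O)Nc1nccs1)c1ccc(Cl)cc1` gives 46000 nM and compound 2 `CC(C)C[C@H](C(=O)Nc1nccs1)c1ccc(Cl)cc1` gives 600 nM. Compound 4 `C=CC[C@H](C(=O)Nc1nccs1)c1ccc(Cl)cc1` carries vinyl in place of methoxymethyl on a saturated chain carbon, two bonds along the chain from an aromatic carbon and a carbonyl carbon. Within the data shown here, three steps bear on this change: a 3.7-fold higher number from compound 1 to compound 3 (0.57 log units; beyond the scatter), a 77-fold lower number from compound 1 to compound 2 (1.88 log units; beyond the scatter) and a 280-fold higher number from compound 2 to compound 3 (2.45 log units; beyond the scatter). Because a 3.7-fold higher number from compound 1 to compound 3 (0.57 log units; beyond the scatter) runs upward on adding the oxygen-bearing group while a 77-fold lower number from compound 1 to compound 2 (1.88 log units; beyond the scatter) runs downward on adding a hydrocarbon branch, a lower number than compound 3 is expected for compound 4, though short of compound 2. Compound 4 is thus expected to give 8000 nM (range 1500 nM to 40000 nM), an estimated step of a 21-fold lower number from compound 3 to compound 4 (1.33 log units; beyond the scatter).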

Compound 4, half-maximal inhibitory concentration: 1100 nM
For compound 4 the middle estimate is 7.3-fold (0.86 log units) above the measured one; measured number below the stated range.
By their numbers in this assay, from the lowest: compounds 2 and 4 (each within the scatter of the next); then compound 1; then compound 3.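

Going from 2-methoxyethyl to allyl gives a 150-fold lower number from compound 3 to compound 4 (2.19 log units; beyond the scatter) at this place, so the high number of compound 3 is not shared by this unbranched hydrocarbon chain. With a 42-fold lower number from compound 1 to compound 4 (1.62 log units; beyond the scatter) as well, a large fall from compound 1 does not require the branched end of compound 2, and a 1.8-fold higher number from compound 2 to compound 4 (0.26 log units; within the scatter) leaves compound 2 and compound 4 unseparated on this read-out.

Going by these compounds, whether a longer chain, a benzyl group or an amine at this place would match compound 2 and compound 4 stays open, as does whether the ether oxygen alone sets compound 3 apart. Nothing shown gives a reason for these steps.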